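The source may hold more compounds than are shown below. What is called first, only, known or untested is meant among the compounds shown, and "the series" means these compounds.

In an in vitro functional assay on HEK285-7 cells for antagonist activity at prostaglandin D2 receptor 2 (Homo sapiens), read by BRET and beta-arrestin recruitment (on this read-out higher numbers stand for weaker inhibition and lower numbers for stronger inhibition), three compounds have been measured so far. Compound 1 `O=C(O)Cc1sc(Nc2ccccc2)nc1-c1ccc(F)cc1` gives 1300 nM, compound 2 `O=C(O)Cc1sc(Nc2ccc(Cl)cc2)nc1-c1ccc(F)cc1` gives 1900 nM, and compound 3 `O=C(O)Cc1sc(Cc2ccc(Cl)cc2)nc1-c1ccccc1` gives 580 nM, the lowest of the three. Compound 2 differs from compound 1 by chloro in place of hydrogen on an aromatic carbon, and that change made a 1.5-fold higher number from compound 1 to compound 2 (0.16 log units; within the scatter). Compound 3 is built on a different core; how its core differs from that of compound 1 is not broken down here. Among the compounds with values here, compound 4 `O=C(O)Cc1sc(Cc2ccc(Cl)cc2)nc1-c1ccc(Cl)cc1` has not yet been measured in this assay; it differs from compound 3 by chloro in place of hydrogen on an aromatic carbon, the same change as the one from compound 1 to compound 2. Because that earlier change gave a 1.5-fold higher number from compound 1 to compound 2 (0.16 log units; within the scatter), a similar small step is expected here, about a 1.3-fold higher number from compound 3 to compound 4 (0.11 log units; within the scatter). The estimate for compound 4 is therefore 750 nM, with a likely range from 300 nM to 1900 nM.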

Compound 4, half-maximal inhibitory concentration: 220 nM
Estimate against measurement, compound 4: 3.4-fold (0.53 log units) above; measured number outside the range, below it.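

In this assay, chloro in place of hydrogen, here phenyl to 4-chlorophenyl, gave a 2.6-fold lower number from compound 3 to compound 4 (0.42 log units; beyond the scatter), so the change did not behave as it had on the core of compound 1. The two cores give clearly different results for this one change, so a result from one core cannot simply be carried to the other: the same change on two cores in this assay, a 1.5-fold higher number (0.16 log units; within the scatter) from compound 1 to compound 2 and a 2.6-fold lower number (0.42 log units; beyond the scatter) from compound 3 to compound 4, 3.9-fold (0.59 log units) apart, beyond the scatter of two such steps. Within the data shown here, this rests on only one pair of compounds per core, and it does not show why the results differ or what the change would do on a third core.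

The compounds shown leave open whether a methoxy group or a nitrile in the place of this chloro would also lower the number on the core of compound 3. They also leave open whether an amine there would do so.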